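The source may hold more compounds than are shown below. What is called first, only, known or untested is meant among the compounds shown, and "the series" means these compounds.

The three measured compounds, with their results in a functional assay on HCT-116 cells (Homo sapiens) for cytotoxicity, read by MTT assay, with a stated time of 48 h; on this read-out higher numbers stand for weaker inhibition of growth and lower numbers for stronger inhibition of growth:

Compound 1, `CCn1c(C(F)(F)F)nc2cc(Cl)c(Cl)cc21`, gives 95300 nM.
Compound 2, `CC(C)n1c(C(F)(F)F)nc2cc(Cl)c(Cl)cc21`, gives 81900 nM.
Compound 3, `Cc1nc2cc(Cl)c(Cl)cc2n1C1CCCC1`, gives 13000 nM.

Compound 1 and compound 2 share one core and differ in a single spot: methyl in place of hydrogen on a saturated chain carbon bound to an aromatic nitrogen and a saturated chain carbon. That change gave a 1.2-fold lower number from compound 1 to compound 2 (0.07 log units; within the scatter), so the two numbers cannot be told apart by this measurement. Compound 3 sits on a different core, and the difference between the two cores is not broken down here; only the two values can be set side by side, and in this assay compound 3 gives 13000 nM against the numbers for compound 1 and compound 2 given above, a gap that is beyond the scatter.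

Compound 4, `CCc1nc2cc(Cl)c(Cl)cc2n1C1CCCC1`, has not yet been measured in this assay. It is built from compound 3 by methyl in place of hydrogen on a saturated chain carbon bound to an aromatic carbon. Among the measured compounds shown here, this is the same kind of change as the one from compound 1 to compound 2, but not the same: there the place was a saturated chain carbon bound to an aromatic nitrogen and a saturated chain carbon, here it is a saturated chain carbon bound to an aromatic carbon. For the measured compounds named here, the one earlier example of this kind of change stayed within the scatter, so a small step is expected here as well, with the wider uncertainty that comes from the different place and core. Going by the values given here, the step from compound 3 to compound 4 is expected to be about a 1.1-fold lower number from compound 3 to compound 4 (0.03 log units; within the scatter), because the only comparable step, a 1.2-fold lower number from compound 1 to compound 2 (0.07 log units; within the scatter), was small. Compound 4 is therefore estimated at 12000 nM, with a likely range from 5000 nM to 30000 nM.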

Compound 4, concentration for 50% growth inhibition: 38000 nM
Estimate against measurement, compound 4: 3.2-fold (0.50 log units) below, outside the stated range (above it).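

In this assay, adding one methyl to compound 3, which turns its methyl group into an ethyl group, was not the small step that the earlier pair had suggested: the result was a 2.9-fold higher number from compound 3 to compound 4 (0.47 log units; beyond the scatter). Set beside the earlier step, the same kind of change clearly did not carry over unchanged from one core to the other: the same change on two cores in this assay, a 1.2-fold lower number (0.07 log units; within the scatter) from compound 1 to compound 2 and a 2.9-fold higher number (0.47 log units; beyond the scatter) from compound 3 to compound 4, 3.4-fold (0.53 log units) apart, beyond the scatter of two such steps. This shows that, in this series, the size of a step seen on one core cannot simply be transferred to another, but it rests on one pair per core, with the added methyl in a different place in each pair, so the data cannot say whether the core, the place or both set the size of the step, and they give no mechanism for the difference.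

From the compounds shown here alone, it remains open whether a longer chain such as propyl on the same saturated chain carbon would raise the number further, or whether an amine or a carboxylic acid there would give a different result. Also open is which part of the difference between the two cores matters, since those cores differ in more than one place and no pair shown separates those differences.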